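From compound 2 to compound 3: one group exchanged

This account rests on a few compounds, and the source may have more. Where it says the series, first, only, none or still open, it means among the compounds named here.

Measured in an ADME assay on microsomes from liver (Homo sapiens) for metabolic stability, using NADPH, with a stated time of 10 min; a higher number here means that more of the compound is left, a lower number that less of the compound is left:
Compound 1 `CN(C)C1CCN(c2cccc3c2C[C@H](CN(C)[C@H]2CCCc4cccnc42)NC3)CC1`: 78.4%
Compound 2 `CN1CC[C@H]2CN(c3cccc4c3C[C@H](CN(C)[C@H]3CCCc5cccnc53)NC4)C[C@H]21`: 87.3%

Among the measured compounds shown here, the only measured step is a number 8.9 percentage points higher from compound 1 to compound 2 (within the scatter), so compound 2 stands level, within the scatter, with the one other measured compound. Compound 3 `CN(C[C@H]1Cc2c(cccc2N[C@H]2CC[C@H](N)CC2)CN1)[C@H]1CCCc2cccnc21` carries a single change from compound 2: a group of 8 heavy atoms (6 carbon, 2 nitrogen; one six-membered non-aromatic ring of carbon only) in place of a group of 9 heavy atoms (7 carbon, 2 nitrogen; 2 five-membered non-aromatic rings with 1 hetero atom each), on an aromatic carbon. The (4-aminocyclohexyl)amino group has not been measured on this core. For the measured compounds named here, the one guide is therefore a number 8.9 percentage points higher from compound 1 to compound 2 (within the scatter), an exchange on the same aromatic carbon, and it bears only loosely. The expected step is a number 5.3 percentage points lower from compound 2 to compound 3 (within the scatter), with no shift beyond the scatter anticipated. For compound 3 the estimate is 82%, expected to fall between 64% and 94%.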

Compound 3, percent of the compound remaining: 100%
Beside the measured number, compound 3's estimate is 18 percentage points below it; the measured number lies above the stated range.
By their numbers in this assay, from the lowest: compounds 1 and 2 (each within the scatter of the next); then compound 3.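

In this assay, the group on this aromatic carbon can move the number beyond the scatter: (4-aminocyclohexyl)amino gives a number 12.7 percentage points higher from compound 2 to compound 3 (beyond the scatter) and a number 21.6 percentage points higher from compound 1 to compound 3 (beyond the scatter). Among the compounds shown here, the one exchange among the earlier groups had stayed within the scatter, so this is the first change at the position that separates two compounds. Nothing measured here accounts for the gain.

The compounds shown leave open whether the gain goes with the carbon-only ring or with its amino group. A 4-hydroxycyclohexylamino group or a cyclohexylamino group without the amine at this position would begin to separate the two.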